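Methoxy for Methyl: Compound 4 Expected from Compound 2

The source may hold more compounds than are shown below. What is called first, only, known or untested is meant among the compounds shown, and "the series" means these compounds.

Measured compounds:
compound 1, `O=c1[nH]nc2n(c1=O)CCN2c1ccccc1`, 0%
compound 2, `Cc1ccc(N2CCN/C2=N\N)cc1`, 17%
compound 3, `N=c1c(=O)[nH]nc2n1CCN2c1cccc(Cl)c1`, 31%

In a functional assay on T47D cells (Homo sapiens) for cytotoxicity, with a stated time of 72 h, tested at 50 ug/mL (on this read-out lower numbers stand for a weaker effect and higher numbers for a stronger effect at the one concentration tested), compound 1 gives 0%, compound 2 gives 17%, and compound 3 gives 31%. Compound 2 thus stands second highest of the three numbers in this assay: its nearest neighbour is compound 3, which lies higher by an amount beyond the scatter, and the furthest is compound 1, which lies lower, again beyond the scatter. Among the compounds with values here, no pair of measured compounds differs in one place only, so no single step has been measured among them.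

Compound 4, `COc1ccc(N2CCN/C2=N\N)cc1`, is not yet measured in this assay. It differs from compound 2 by one exchange on the aromatic ring: methoxy in place of methyl on an aromatic carbon. Among the measured compounds there is no pair showing what such an exchange does in this assay, so the expectation rests on compound 2 alone. Compound 2 gives 17%, and the step from compound 2 to compound 4 is expected to be small, a number 1 percentage points higher from compound 2 to compound 4 (within the scatter), not beyond the scatter in either direction. Compound 4 is therefore estimated at 18%, within a range from 5% to 35%.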

Compound 4, a percentage reported as inhibition, at one concentration (the size of the read-out at that concentration, not a potency): 23%
Compound 4: the middle estimate sits 5 percentage points below what was measured, and the stated range covers the measured number.
By their numbers in this assay, from the lowest: compound 1; then compounds 2, 4 and 3 (each within the scatter of the next, the first and the last beyond it).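

In this assay, the exchange of methyl for methoxy now has a measured step: a number 6 percentage points higher from compound 2 to compound 4 (within the scatter). This is the first single change read among these compounds, and it shows that on this aromatic carbon, para to a group of 7 heavy atoms, the added oxygen and its hydrogen-bond acceptor give a read-out that cannot be told apart from that of the methyl compound. Nothing at hand explains this result.

As far as these compounds go, whether an amine, a carboxylic acid or a longer chain at this same place would give a step beyond the scatter remains open. From the compounds shown here alone, it is also open whether methoxy in place of methyl would give a similar step on the core of compound 3.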